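A few compounds are considered here, and "the series" means these few. Any claim that something is new, unique, unknown or untested is made for them only; others in the source may bear on it.

Compound 1 `CC1CCN(c2c(S(=O)(=O)c3cc(F)cc(F)c3)cnc3c(F)cccc23)CC1` gives 9% in an assay on isolated protein for displacement of a labelled ligand from metabotropic glutamate receptor 5 (Homo sapiens), with a stated time of 60 min, tested at 1 uM; on this read-out lower numbers stand for less inhibition and higher numbers for more inhibition at the one concentration tested (going by the name of the read-out). Compound 2 `CC1CCN(c2c(S(=O)(=O)c3cccc(F)c3)cnc3c(F)cccc23)CC1` gives 62% in this assay, the step of a number 53 percentage points higher from compound 1 to compound 2 (beyond the scatter) being the only measured one in this pair. Compound 2 therefore stands highest of the two numbers, with compound 1 the nearest and well below it. Compound 3 `CC1CCN(c2c(S(=O)(=O)c3ccc(F)cc3)cnc3c(F)cccc23)CC1` differs from compound 2 by 4-fluorophenyl in place of 3-fluorophenyl on a sulfonyl sulfur. The step from compound 1 to compound 2 concerns a fluoro removed from the ring on the sulfonyl sulfur, not one moved within it, so it bears only loosely; a step of a number 7 percentage points lower from compound 2 to compound 3 (within the scatter) is expected, small and within the scatter. For compound 3 the estimate is 55%, within 25% to 80%.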

Compound 3, a percentage reported as inhibition, at one concentration (the size of the read-out at that concentration, not a potency): 26%
Estimate against measurement, compound 3: 29 percentage points above, within the range that was stated.
By their numbers in this assay, from the lowest: compound 1; then compound 3; then compound 2.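

In this assay, 4-fluorophenyl in place of 3-fluorophenyl on the sulfonyl sulfur gives a number 36 percentage points lower from compound 2 to compound 3 (beyond the scatter) even though the two compounds have the same atoms, so the place of one fluoro on this ring counts, not only the number of fluoro groups. 4-Fluorophenyl in place of 3,5-difluorophenyl gives a number 17 percentage points higher from compound 1 to compound 3 (beyond the scatter) and recovers only part of what removing one fluoro gave in compound 2. Nothing available accounts for these differences. Still open, from the compounds shown here alone, is whether phenyl, 3-chlorophenyl or 3-methoxyphenyl on the sulfonyl sulfur would match the number seen with 3-fluorophenyl.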